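This account rests on a few compounds, and the source may have more. Where it says the series, first, only, none or still open, it means among the compounds named here.

Measured so far:
- Compound 1 `O=C(O)C(=O)CC(=O)c1ccc(-c2ccccc2)o1`: 1660 nM
- Compound 2 `O=C(O)C(=O)CC(=O)c1ccc(-c2ccc(Cl)cc2)o1`: 10800 nM

Among the measured compounds shown here, in an assay on isolated protein for inhibition of Flap endonuclease 1 (Homo sapiens) (on this read-out higher numbers stand for weaker inhibition and lower numbers for stronger inhibition), compound 2 gives the higher of the two numbers; its only neighbour is compound 1, and the step of a 6.5-fold higher number from compound 1 to compound 2 (0.81 log units; beyond the scatter) separates them. Compound 3 `CCOc1ccc(-c2ccc(C(=O)CC(=O)C(=O)O)o2)cc1` differs from compound 2 in one place: ethoxy in place of chloro on an aromatic carbon, on an aromatic carbon of a six-membered aromatic ring of carbon only, para to a large group. For the measured compounds named here, no measured step exchanges chloro for another group, so none bears on this change directly. Going by the values given here, the only comparison at this position, a 6.5-fold higher number from compound 1 to compound 2 (0.81 log units; beyond the scatter), shows that placing chloro there raised the number relative to hydrogen; whether an ethoxy group behaves like chloro, like hydrogen, or differently is not known from these two compounds. For compound 3 a step of a 1.5-fold lower number from compound 2 to compound 3 (0.19 log units; within the scatter) in this assay is expected, with wide uncertainty. The estimate for compound 3 is 7000 nM, within a range of 2000 nM to 25000 nM.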

Compound 3, half-maximal inhibitory concentration: 11300 nM
For compound 3 the middle estimate is 1.6-fold (0.21 log units) below the measured one; the measured number falls inside the stated range.
By their numbers in this assay, from the lowest: compound 1; then compounds 2 and 3 (each within the scatter of the next).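

In this assay, the swap of chloro for ethoxy at this position gives a 1.0-fold higher number from compound 2 to compound 3 (0.02 log units; within the scatter), so the two groups cannot be told apart here. Ethoxy in place of hydrogen gives a 6.8-fold higher number from compound 1 to compound 3 (0.83 log units; beyond the scatter), which means a second group, not chloro alone, now sits beyond the scatter from the hydrogen of compound 1, in the direction of weaker inhibition. Nothing available explains why two groups with different atoms give such similar numbers.

Still open is whether any group at this position can match or improve on hydrogen, as the only two groups shown both give weaker inhibition. An amine, a carboxylic acid or a longer chain than ethoxy could each answer that, and the compounds shown do not say which way they would go.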